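The compounds below may be only part of what the source reports. "The series", "measured", "known", "first", "only" and "open" are said of these compounds alone.

In an ADME assay on a cell-free system (plasma, Homo sapiens) for protein binding, compound 1 `COCc1nc2nc(C)cc(Nc3ccc(C(F)(F)F)cc3)n2n1` gives 75.6%, while compound 2 `CSc1nc2nc(C)cc(Nc3ccc(S(F)(F)(F)(F)F)cc3)n2n1` gives 97.7%. Compound 2 therefore has the lower unbound fraction of the two, and the gap lies beyond the usual scatter. Compound 3 `CSc1nc2nc(C)cc(Nc3ccc(C(F)(F)F)cc3)n2n1` differs from compound 2 in one place: a group of 4 heavy atoms (1 carbon, 3 fluorine; no ring) in place of a group of 6 heavy atoms (5 fluorine, 1 sulfur; no ring), on an aromatic carbon. Trifluoromethyl enters on an aromatic carbon, para to a large group. Among the measured compounds shown here, no measured step shows what this swap does, so only a modest shift towards more free compound, slightly beyond the scatter, is expected. The expected step is a 2.6-fold higher unbound fraction from compound 2 to compound 3 (0.42 log units; beyond the scatter). Compound 3 is estimated at 94%, with a range of 88% to 97.5%.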

Compound 3, plasma protein binding: 91.8%
The estimate for compound 3 lay 1.4-fold (0.14 log units) (unbound fraction) below the measured number; the measured number falls inside the stated range.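

In this assay, trifluoromethyl in place of the group of 5 fluorine and 1 sulfur on the aromatic carbon gives a 3.6-fold higher unbound fraction from compound 2 to compound 3 (0.55 log units; beyond the scatter), so this change alone moves binding beyond the scatter. Methylsulfanyl in place of methoxymethyl gives a 3.0-fold lower unbound fraction from compound 1 to compound 3 (0.47 log units; beyond the scatter), showing that this second place also matters when the rest of the molecule stays the same. The large gap between compound 1 and compound 2 therefore reflects changes at both places.

As far as these compounds go, whether an amine on the aromatic carbon, or a carboxylic acid in place of methylsulfanyl, would leave more compound free remains open. Nothing available explains either shift.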